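This account rests on a few compounds, and the source may have more. Where it says the series, first, only, none or still open, it means among the compounds named here.

Among the compounds with values here, compound 2 `COc1ccc(-c2ncnn2-c2cc(OC)c(OC)c(OC)c2)cc1` is the only compound of this small set to give a number in a functional assay on MCF7 cells (Homo sapiens) for antiproliferative activity, read by MTT assay, with a stated time of 72 h; a higher number here means a weaker inhibitor, a lower number a stronger inhibitor; in this assay compound 2 gives 360 nM. Compound 1 `COc1cc(-n2ncnc2-c2cccc(F)c2)cc(OC)c1OC` reaches only a limit of the assay, giving > 10000 nM. Compound 3 `COc1cc(-n2ncnc2-c2cccc(Cl)c2)cc(OC)c1OC` likewise stops at a limit, giving > 10000 nM. The two readable steps are large: an at least 27-fold lower number from compound 1 to compound 2 (1.44 log units; beyond the scatter), and an at least 27-fold higher number from compound 2 to compound 3 (1.44 log units; beyond the scatter). The step that the two limits leave unreadable from compound 1 to compound 3 cannot be read, as both of its ends sit at the limit of > 10000 nM in this assay, at which 2 of the 3 values shown sit. Compound 4 `COc1cc(-n2ncnc2-c2ccc(OC(F)(F)F)cc2)cc(OC)c1OC` differs from compound 2 only on the oxygen of the 4-methoxyphenyl group: trifluoromethyl in place of methyl on an oxygen on an aromatic ring. Within the data shown here, no measured step touches this oxygen; the measured steps all concern exchange of the whole aryl group, and compound 4 keeps the aryl pattern of compound 2 rather than that of compound 1 or compound 3. A number rather than a limit is therefore expected for compound 4, with a modest weakening estimated as a 3.3-fold higher number from compound 2 to compound 4 (0.52 log units; beyond the scatter). The estimate for compound 4 in this assay is 1200 nM, within a range from 300 nM to 6000 nM.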

Compound 4, half-maximal inhibitory concentration: > 10000 nM
Compound 4 gave a limit, no number; the forecaster's own chance of this, stated with the estimate: 20%; middle value at least 8.3-fold (0.92 log units) away from the limit.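

Within the data shown here, until this compound, the only exchanges in the set replaced the whole aryl group; here only the group on the oxygen changes, methoxy to trifluoromethoxy, and that alone gives an at least 27-fold higher number from compound 2 to compound 4 (1.44 log units; beyond the scatter) in this assay. The aryl pattern of compound 2 therefore does not by itself secure a number, since the group on this oxygen also matters. Compound 4 stops at a limit of the assay, and compound 2 remains the only compound with a number: the limit of > 10000 nM in this assay, at which 3 of the 4 values shown sit.

As far as these compounds go, no order can be read among the compounds at this limit, and how far the step from compound 2 really extends stays unknown. From the compounds shown here alone, it also remains open whether the number is lost only with trifluoromethyl or also with an ethyl group, a longer chain or an amine at this position.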